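This account rests on a few compounds, and the source may have more. Where it says the series, first, only, none or still open, it means among the compounds named here.

In an ADME assay on TZM-b1 cells (Homo sapiens) for cytotoxicity, read by XTT assay, with a stated time of 3 days (on this read-out higher numbers stand for lower toxicity in this test and lower numbers for higher toxicity in this test), compound 1 `Cc1nc(C(NC(=O)C(=O)Nc2ccc(Cl)cc2)C2CCNCC2)sc1CO` gives 81000 nM, compound 2 `Cc1nc(C(NC(=O)C(=O)Nc2ccc(Cl)c(F)c2)C2CCCCN2)sc1CO` gives 58400 nM, and compound 3 `Cc1nc(C(NC(=O)C(=O)Nc2ccc(Cl)c(F)c2)C2CCCCN2)sc1CCO` gives 61000 nM. Compound 2 stands with the other two inside the scatter: the step of a 1.0-fold higher number from compound 2 to compound 3 (0.02 log units; within the scatter) is negligible, and the gap between compound 2 and compound 1 is likewise within the scatter, so nothing separates the three in this assay.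

Compound 4 `CC(=O)c1ccc(NC(=O)C(=O)NC(c2nc(C)c(CO)s2)C2CCCCN2)cc1` is reached from compound 2 by the change (4-acetylphenyl in place of 4-chloro-3-fluorophenyl on an amide-type nitrogen). For the measured compounds named here, no measured step bears on this change. Going by the values given here, the only single-point step among the measured compounds, a 1.0-fold higher number from compound 2 to compound 3 (0.02 log units; within the scatter), touches a different part of the molecule and is flat, and compound 1 differs from compound 2 in more than one place, so it yields no clean reading on the aryl group either. With no evidence pointing in either direction, the step of a 1.0-fold higher number from compound 2 to compound 4 (0.01 log units; within the scatter) is expected to stay within the scatter. Compound 4 is therefore estimated at 60000 nM in this assay, with a range from 25000 nM to 140000 nM.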

Compound 4, half-maximal cytotoxic concentration: > 86000 nM
Compound 4 was reported as a limit (the forecaster's own chance of this, stated with the estimate: 20%); at least 1.4-fold (0.15 log units) between middle value and limit.
By their numbers in this assay, from the lowest: compounds 2, 3 and 1 (each within the scatter of the next). At a limit, above all of these: compound 4.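

For the compounds shown here, compound 4 gives the first reading of a single change on the amide-type nitrogen, a place that the earlier steps left untouched. In this assay, 4-acetylphenyl in place of 4-chloro-3-fluorophenyl gives an at least 1.4-fold higher number from compound 2 to compound 4 (0.16 log units; that floor lies within the scatter), so this step is only a floor and shows no lower number with the new aryl group. The value for compound 4 is a limit, and the reading of this change ends there: the limit of > 86000 nM in this assay, at which 1 of the 4 values shown sits.

On these data alone, how far the number of compound 4 lies from that of compound 2 stays open, so the size of this change is unknown. Also open, as far as these compounds go, is whether an amine or a carboxylic acid in place of the acetyl group would give a similar reading in this assay, and whether the same aryl change would read alike on the core of compound 3.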